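Dropping One Fluoro from the Difluorophenyl Ring

This account rests on a few compounds, and the source may have more. Where it says the series, first, only, none or still open, it means among the compounds named here.

Compound 1 `COc1ccc(S(=O)(=O)N2CCc3cccc(-c4ccc(F)nc4)c32)cc1` gives 143 nM
Compound 2 `COc1ccc(S(=O)(=O)N2CCc3cccc(-c4ccc(F)c(F)c4)c32)cc1` gives 45 nM
Compound 3 `COc1ccc(S(=O)(=O)N2CCc3cccc(-c4ccc(F)cc4)c32)cc1` has not yet been measured

In a functional assay on KB cells (Homo sapiens) for inhibition, with a stated time of 72 h (a lower number here means a stronger inhibitor, a higher number a weaker inhibitor), compound 2 gives 45 nM, the lower of the two numbers and so the stronger inhibitor, with a gap to compound 1 beyond the scatter. Compound 3 differs from it as follows: hydrogen in place of fluoro on an aromatic carbon. In words, this is hydrogen in place of fluoro on an aromatic carbon, turning 3,4-difluorophenyl into 4-fluorophenyl. Among the measured compounds shown here, only one measured step bears on this: a 3.2-fold lower number from compound 1 to compound 2 (0.50 log units; beyond the scatter). That step replaced a whole ring, 6-fluoropyridin-3-yl, so it is a loose guide to this smaller edit. For the measured compounds named here, no measured pair shows this fluoro being removed, so no direction can be firmly expected. The expected change is small, within the scatter: a 1.2-fold higher number from compound 2 to compound 3 (0.09 log units; within the scatter). Compound 3 is estimated at 55 nM, with an expected range of 22 nM to 135 nM.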

Compound 3, half-maximal inhibitory concentration: 86 nM
The estimate for compound 3 lay 1.6-fold (0.19 log units) below the measured number; the range from low to high includes it.
By their numbers in this assay, from the lowest: compounds 2, 3 and 1 (each within the scatter of the next, the first and the last beyond it).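

In this assay, the removal of one fluoro from the 3,4-difluorophenyl ring gives a 1.9-fold higher number from compound 2 to compound 3 (0.28 log units; within the scatter) and so, on this read-out, this fluoro cannot be shown to matter. With 4-fluorophenyl in place of 6-fluoropyridin-3-yl, the result is a 1.7-fold lower number from compound 1 to compound 3 (0.22 log units; within the scatter) and so compound 3 lies within the scatter of both earlier compounds, even though those two lie beyond the scatter of each other. No supporting measurement is available to explain these numbers.

The compounds shown leave open whether a different group on this aromatic carbon, such as an amine or a carboxylic acid, would give a number beyond the scatter of compound 2. They also leave open what a plain phenyl ring, with no fluoro at all, would give.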